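Trimming the Chain from Compound 2 to Compound 3

A few compounds are considered here, and "the series" means these few. Any claim that something is new, unique, unknown or untested is made for them only; others in the source may bear on it.

Compound 1 `CCCCCCCCCc1cccc(N2CCNCC2)n1`: 10 mg/kg
Compound 2 `CCCCCCc1cccc(N2CCNCC2)n1`: 10 mg/kg

Of the compounds shown here, two have been tested so far in a functional assay on the whole organism with Mus musculus as the target, in the maximal electroshock model, with a stated time of 120 min; on this read-out higher numbers stand for an effect only at larger amounts of compound and lower numbers for an effect already at smaller amounts. Compound 1 gives 10 mg/kg and compound 2 gives 10 mg/kg. Among the compounds with values here, the one step measured between them, no change at the digits printed from compound 1 to compound 2 (within the scatter), left the minimum effective dose where it was, so compound 2 stands level with compound 1 on the numbers in hand.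

Compound 3 `CCCCc1cccc(N2CCNCC2)n1` has not yet been measured. It differs from compound 2 by hydrogen in place of ethyl on a saturated chain carbon, four bonds along the chain from an aromatic carbon. Within the data shown here, the only measured step that bears on this change is the shortening of the same chain, no change at the digits printed from compound 1 to compound 2 (within the scatter), which made no difference beyond the scatter. On that basis the step from compound 2 to compound 3 is expected to be no change at the digits printed from compound 2 to compound 3 (within the scatter), no change beyond the scatter, though a single prior step is thin evidence and the chain is now shorter than in either measured compound. Compound 3 is therefore estimated at 10 mg/kg in this assay, with a range of 5 mg/kg to 25 mg/kg.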

Compound 3, minimum effective dose: 30 mg/kg
For compound 3 the middle estimate is 3.0-fold (0.48 log units) below the measured one; measured number above the stated range.
By their numbers in this assay, from the lowest: compounds 1 and 2 (each within the scatter of the next); then compound 3.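

In this assay, within the data shown here, this change on a saturated chain carbon, four bonds along the chain from an aromatic carbon, is the first to register beyond the scatter: hydrogen in place of ethyl gives a 3.0-fold higher number from compound 2 to compound 3 (0.48 log units; beyond the scatter), whereas the earlier shortening gave no change at the digits printed from compound 1 to compound 2 (within the scatter). Measured from the longest chain shown, hydrogen in place of pentyl at the same place gives a 3.0-fold higher number from compound 1 to compound 3 (0.48 log units; beyond the scatter), a step of the same printed size, and it too is modest. The read-out therefore does not track chain length evenly across these compounds: compounds 1 and 2 stand level, and only compound 3 separates from them, so chain length matters here, but not at every length shown.

No measurement is available that bears on what lies behind this difference. From the compounds shown here alone, it remains open whether the number would rise further with a propyl, ethyl or methyl group in place of the chain of compound 3, and whether a chain of similar length ending in a hydroxyl group or an amine would stand with compound 3 or with compounds 1 and 2.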